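Urea series with a chloropyrazine core: halogen swap on the aryl ring

The compounds below may be only part of what the source reports. "The series", "measured", "known", "first", "only" and "open" are said of these compounds alone.

Measured so far in a functional assay on T-24 cells (Homo sapiens) for antiproliferative activity, read by MTT assay, with a stated time of 48 h; a lower number here means a stronger inhibitor, a higher number a weaker inhibitor:
compound 1 `O=C(Nc1cccc(CNc2nccnc2Cl)c1)Nc1ccc(F)c(Cl)c1` — 4990 nM
compound 2 `CC(C)(C)c1ccc(NC(=O)Nc2cccc(CNc3nccnc3Cl)c2)cc1` — 6010 nM
compound 3 `CCc1ccc(NC(=O)Nc2cccc(CNc3nccnc3Cl)c2)c(CC)c1` — 6390 nM

All three compounds share the same core and differ only in the aryl group on the urea. Compound 1 sits alongside compound 2 and compound 3; the gaps among the three numbers fall within the usual scatter of this assay, so no order can be read from them.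

Compound 4 `O=C(Nc1cccc(CNc2nccnc2Cl)c1)Nc1ccc(Cl)c(Cl)c1`, not yet measured, differs from compound 1 in one place: chloro in place of fluoro on an aromatic carbon.

Going by the values given here, no step between measured compounds bears on this change, so the expectation rests on the structural change alone. The step from a fluoro to a chloro at this place is expected to be small, with no direction beyond the scatter: a 1.1-fold lower number from compound 1 to compound 4 (0.04 log units; within the scatter). Compound 4 is therefore estimated at 4500 nM, within a range of 2000 nM to 10000 nM.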

Compound 4, half-maximal inhibitory concentration: 5210 nM
Compound 4: middle estimate off by 1.2-fold (0.06 log units), on the low side; the range from low to high includes it.
By their numbers in this assay, from the lowest: compounds 1, 4, 2 and 3 (each within the scatter of the next).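

In this assay, the change from 3-chloro-4-fluorophenyl to 3,4-dichlorophenyl gives a 1.0-fold higher number from compound 1 to compound 4 (0.02 log units; within the scatter), so chloro in place of fluoro at this position, para to a large group, leaves the number within the scatter. Going by these compounds alone, no earlier pair of compounds differed in one place, so this is the first direct reading of a single change. No measurement at hand gives a reason for this result. From the compounds shown here alone, it remains open whether an amine, a carboxylic acid or a methoxy group at this position would move the number beyond the scatter.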